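A few compounds are considered here, and "the series" means these few. Any claim that something is new, unique, unknown or untested is made for them only; others in the source may bear on it.

Compound 1 `CC(C)c1n[nH]c2c(NCc3ccc(-c4ccccn4)cc3)nc(SC(C)C(C)O)nc12` has the lowest number of the three measured compounds in a functional assay on HT cells (Homo sapiens) for antiproliferative activity, read by fluorescence, with a stated time of 72 h (on this read-out higher numbers stand for weaker inhibition of growth and lower numbers for stronger inhibition of growth), giving 190 nM. Compound 2 `CC(C)c1n[nH]c2c(NCc3ccc(-c4ccccn4)cc3)nc(SCC(O)CN3CCNCC3)nc12` gives 332 nM in this assay, and compound 3 `CC(C)c1n[nH]c2c(NCc3ccc(-c4ccccn4)cc3)nc(SC3CCCC3O)nc12` gives 567 nM. The step of a 1.7-fold higher number from compound 1 to compound 2 (0.24 log units; within the scatter) stays within the scatter, whereas the step of a 3.0-fold higher number from compound 1 to compound 3 (0.47 log units; beyond the scatter) is a modest loss of activity; the values of compound 2 and compound 3 lie within the scatter of each other, as a 1.7-fold higher number from compound 2 to compound 3 (0.23 log units; within the scatter) shows.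

Compound 4 `COCSc1nc(NCc2ccc(-c3ccccn3)cc2)c2[nH]nc(C(C)C)c2n1` differs from compound 1 in a single place: methoxymethyl in place of 2-hydroxy-1-methylpropyl on a sulfur. Both measured steps from compound 1 change the group on this sulfur while keeping a hydroxyl within it; here the hydroxyl leaves and no such group enters, so those steps are only a rough guide. They show that altering this group costs anywhere from nothing to a modest amount. Compound 4 is therefore expected to sit somewhat higher, with an estimated step of a 2.0-fold higher number from compound 1 to compound 4 (0.30 log units; within the scatter). The estimate for compound 4 in this assay is 380 nM, expected to fall between 150 nM and 950 nM.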

Compound 4, concentration for 50% growth inhibition: 340 nM
Compound 4: middle estimate off by 1.1-fold (0.05 log units), on the high side, within the range that was stated.
By their numbers in this assay, from the lowest: compounds 1, 2, 4 and 3 (each within the scatter of the next, the first and the last beyond it).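

In this assay, within the data shown here, the step from the hydroxyl-bearing group to methoxymethyl is a 1.8-fold higher number from compound 1 to compound 4 (0.25 log units; within the scatter), so a group on this sulfur with no hydrogen-bond donor still gives a value in the same range, something the earlier compounds, all of which keep a hydroxyl, could not show. The steps to the other two compounds, a 1.7-fold lower number from compound 3 to compound 4 (0.22 log units; within the scatter) and a 1.0-fold higher number from compound 2 to compound 4 (0.01 log units; within the scatter), likewise stay small, so neither the cyclopentane ring nor the piperazine ring is needed for activity of this size. No measurement offered here gives a reason for these values.

On these data alone, whether any oxygen at all is needed on this sulfur remains open, and a plain propyl chain there would address that. How a carboxylic acid or a simple amine in the same place would read is also unknown.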